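The source may hold more compounds than are shown below. What is called first, only, known or untested is meant among the compounds shown, and "the series" means these compounds.

Measured compounds:
Compound 1, `CC(C)CNC(=O)c1cc2ccccc2oc1=O`, in an in vitro assay on BTI-TN-5B1-4 cells for inhibition of Amine oxidase [flavin-containing] B (Homo sapiens), read by fluorescence (a lower number here means a stronger inhibitor, a higher number a weaker inhibitor), gives 3270 nM.
Compound 2, `O=C(Nc1c(F)c(F)c(F)c(F)c1F)c1cc2ccccc2oc1=O`, in this assay gives 460 nM.

Compound 2 stands lowest of the two numbers; compound 1 lies above it by a gap beyond the scatter. Compound 3, `N#Cc1c(F)c(F)c(NC(=O)c2cc3ccccc3oc2=O)c(F)c1F`, differs from compound 2 by cyano in place of fluoro on an aromatic carbon. For the measured compounds named here, no measured pair shows this change, so the expectation rests on compound 2 alone. The step from compound 2 to compound 3 in this assay is expected to be small, in either direction, and probably within the scatter. Compound 3 is expected to give about 400 nM, between 150 nM and 1200 nM. This estimate means a 1.2-fold lower number from compound 2 to compound 3 (0.06 log units; within the scatter).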

Compound 3, half-maximal inhibitory concentration: 860 nM
Estimate against measurement, compound 3: 2.2-fold (0.33 log units) below, within the range that was stated.
By their numbers in this assay, from the lowest: compounds 2 and 3 (each within the scatter of the next); then compound 1.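

Cyano in place of fluoro on this aromatic carbon, para to a large group, brings a 1.9-fold higher number from compound 2 to compound 3 (0.27 log units; within the scatter) in this assay. At this position, then, the two groups cannot be told apart in this measurement, and a cyano with its hydrogen-bond acceptor is accepted on the ring where only fluoro had been seen. Nothing at hand bears on why the two read alike. The compounds shown leave open how an amine or a carboxylic acid on this same carbon would read.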